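This account rests on a few compounds, and the source may have more. Where it says the series, first, only, none or still open, it means among the compounds named here.

The three measured compounds share one core. Compound 1 `Clc1ccc(Cc2nn3cc(-c4ccc(Br)cc4)nc3s2)cc1` carries a 4-bromophenyl group on it. In a functional assay on L1210 cells (Mus musculus) for cytotoxicity, with a stated time of 48 h (a higher number here means a weaker inhibitor, a lower number a stronger inhibitor), compound 1 gives > 250000 nM, which is a limit of the assay and not a number. Compound 2 `Clc1ccc(Cc2nn3c(Br)c(-c4ccc(Br)cc4)nc3s2)cc1` adds a bromine to that core; in this assay compound 2 gives > 250000 nM, again a limit rather than a number. The step that the two limits leave unreadable from compound 1 to compound 2 cannot be read because of the limit of > 250000 nM in this assay, at which 2 of the 3 values shown sit. Compound 3 `O=Cc1c(-c2ccc(F)cc2)nc2sc(Cc3ccc(Cl)cc3)nn12` is the only one of the three whose value is a number: in this assay compound 3 gives 20000 nM, and it therefore stands alone as the sole readable point. Compound 4 `O=Cc1c(-c2ccc(Br)cc2)nc2sc(Cc3ccc(Cl)cc3)nn12` differs from compound 3 by bromo in place of fluoro on an aromatic carbon. Going by the values given here, no measured step touches this kind of exchange, and the one step that exists is unreadable, so no change beyond the usual scatter is expected. The expected step from compound 3 to compound 4 is no change at the digits printed from compound 3 to compound 4 (within the scatter). Compound 4 is estimated at 20000 nM, with a range from 7000 nM to 60000 nM.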

Compound 4, half-maximal inhibitory concentration: 4600 nM
Beside the measured number, compound 4's estimate is 4.3-fold (0.64 log units) above it; measured number below the stated range.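

Exchanging 4-fluorophenyl for 4-bromophenyl gives a 4.3-fold lower number from compound 3 to compound 4 (0.64 log units; beyond the scatter) in this assay, so the halogen at this place, para to a large group, changes the result by more than the scatter. With the 4-bromophenyl group held fixed, formyl on the shared core gives an at least 54-fold lower number from compound 1 to compound 4 (1.73 log units; beyond the scatter) where it replaces hydrogen and an at least 54-fold lower number from compound 2 to compound 4 (1.73 log units; beyond the scatter) where it replaces bromo, and among the compounds shown only those with formyl give a readable number. The true size of these last two steps stays unknown, since each starts from a limit and not from a number: the limit of > 250000 nM in this assay, at which 2 of the 4 values shown sit.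

The compounds shown leave open how chloro or iodo at the same place on the phenyl ring would compare with fluoro and bromo. They also leave open whether a hydroxymethyl group, a nitrile or a carboxylic acid in place of formyl would give a readable number.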